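The source may report more compounds than this note shows. Statements on the series, on what has been measured and on what is new or still open speak of the compounds shown alone.

Of the compounds shown here, three have been measured in a functional assay on HEK293 cells for antagonist activity at thromboxane A2 receptor (Homo sapiens), read by fluorescence and calcium flux; on this read-out lower numbers stand for stronger inhibition and higher numbers for weaker inhibition. Compound 1 `Cc1ccccc1Oc1ccc(C#N)cc1S(=O)(=O)NC(=O)NC(C)(C)C` gives 1470 nM. Compound 2 `CCCCCNC(=O)NS(=O)(=O)c1cc(C#N)ccc1Oc1ccccc1C` gives 1780 nM, and the change pentyl in place of tert-butyl on an amide-type nitrogen made a 1.2-fold higher number from compound 1 to compound 2 (0.08 log units; within the scatter). Compound 3 `Cc1cccc(Oc2ccc(C#N)cc2S(=O)(=O)NC(=O)NC(C)(C)C)c1` gives 690 nM; it differs from compound 1 in its core by 3-methylphenyl in place of 2-methylphenyl on an oxygen on an aromatic ring, a change that made a 2.1-fold lower number from compound 1 to compound 3 (0.33 log units; beyond the scatter). Compound 4 `CCCCCNC(=O)NS(=O)(=O)c1cc(C#N)ccc1Oc1cccc(C)c1` has not yet been measured in this assay. It carries the core of compound 3 and differs from it by pentyl in place of tert-butyl on an amide-type nitrogen, the same change that was made from compound 1 to compound 2, at the same place. Because a 1.2-fold higher number from compound 1 to compound 2 (0.08 log units; within the scatter) stayed within the scatter, a step of similar size is expected here, a 1.2-fold higher number from compound 3 to compound 4 (0.08 log units; within the scatter). Compound 4 is therefore estimated at 830 nM, with a range from 400 nM to 1700 nM.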

Compound 4, half-maximal inhibitory concentration: 680 nM
Estimate against measurement, compound 4: 1.2-fold (0.09 log units) above, and the stated range covers the measured number.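

In this assay, pentyl in place of tert-butyl on the amide-type nitrogen gave a 1.0-fold lower number from compound 3 to compound 4 (0.01 log units; within the scatter), and the two readings of this change agree: the same change on two cores in this assay, a 1.2-fold higher number (0.08 log units; within the scatter) from compound 1 to compound 2 and a 1.0-fold lower number (0.01 log units; within the scatter) from compound 3 to compound 4, 1.2-fold (0.09 log units) apart, within the scatter of two such steps. With pentyl on that nitrogen, 3-methylphenyl in place of 2-methylphenyl gave a 2.6-fold lower number from compound 2 to compound 4 (0.42 log units; beyond the scatter), which agrees with the earlier step: the same change on two cores in this assay, a 2.1-fold lower number (0.33 log units; beyond the scatter) from compound 1 to compound 3 and a 2.6-fold lower number (0.42 log units; beyond the scatter) from compound 2 to compound 4, 1.2-fold (0.09 log units) apart, within the scatter of two such steps. Both changes therefore carry from one core to the other within these four compounds, but this rests on a single pair of cores in one assay and does not show that either change would carry to any other core.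

The compounds shown leave open whether a longer chain such as octyl, or a cyclohexyl group, on that nitrogen would fit the same picture. They also leave open what a chlorine or a methoxy group in place of the methyl of the 3-methylphenyl group would do.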